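The source may hold more compounds than are shown below. What is called first, only, known or untested is meant among the compounds shown, and "the series" means these compounds.

Compound 1, `CC(C)(C)C1=NN(c2ccc(C(F)(F)F)cc2)C(c2ccc(O)cc2)C1`, and compound 2, `CC(C)(C)C1=NN(c2ccc(F)c(Cl)c2)C(c2ccc(O)cc2)C1`, share a core that carries a tert-butyl group and a 4-hydroxyphenyl group, and differ only in the aryl group on the ring nitrogen. In an assay on isolated protein for inhibition of protein kinase C zeta type (Homo sapiens), with a stated time of 4 min, tested at 62.5 uM (on this read-out lower numbers stand for less inhibition and higher numbers for more inhibition at the one concentration tested (going by the name of the read-out)), compound 1 gives 94.2%, and in this assay compound 2 gives 98.8%. The two numbers sit within the usual scatter of repeated measurements of each other, so no order can be read from them; both show that nearly all of the enzyme activity is suppressed at the concentration tested.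

Compound 3, `CC(C)(C)C1=NN(c2ccc(O)cc2)C(c2ccc(O)cc2)C1`, has not yet been measured. It differs from compound 2 in one place: 4-hydroxyphenyl in place of 3-chloro-4-fluorophenyl on an amine nitrogen in a ring. Going by the values given here, since no measured pair in this set shows what such a change does, the size of the step can only be expected, not computed. With two close and near-complete readings as the only anchors, compound 3 is expected to stay high, and the step of a number 8.8 percentage points lower from compound 2 to compound 3 (within the scatter) is estimated to be small, at most a modest decrease close to the scatter. For compound 3 the expected value in this assay is 90%, with a range from 65% to 99%.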

Compound 3, a percentage reported as inhibition, at one concentration (the size of the read-out at that concentration, not a potency): 40.9%
For compound 3 the middle estimate is 49.1 percentage points above the measured one; measured number below the stated range.
By their numbers in this assay, from the lowest: compound 3; then compounds 1 and 2 (each within the scatter of the next).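

The two earlier compounds suggested that the aryl group on the ring nitrogen could change with little effect, but this position turns out to be sensitive in this assay: putting 4-hydroxyphenyl in place of 3-chloro-4-fluorophenyl gives a number 57.9 percentage points lower from compound 2 to compound 3 (beyond the scatter), and hydroxy in place of trifluoromethyl on an aromatic carbon gives a number 53.3 percentage points lower from compound 1 to compound 3 (beyond the scatter). Both steps end at the same compound and both are large, so among these three compounds the position accepts the trifluoromethyl-bearing and the halogen-bearing aryl groups alike, while the 4-hydroxyphenyl group stands apart from them. Nothing available here gives a measured reason for this drop.

The compounds shown leave open whether the loss goes with the hydroxy group entering or with the trifluoromethyl, chlorine and fluorine leaving, since each step makes both changes at once. On these data alone, an unsubstituted phenyl group on the ring nitrogen, or a methoxy group or an amine on the same aromatic carbon, would be needed to tell these apart, and how any of them would read remains open.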